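The source may report more compounds than this note shows. Statements on the series, on what has been measured and on what is new or still open speak of the compounds shown alone.

Within the data shown here, compound 1 `CCOC(=O)c1sc2ccc(NCc3c[nH]cn3)cc2c1NC(=O)c1ccc(OC)cc1` and compound 2 `CCOC(=O)c1sc2ccc(N)cc2c1NC(=O)c1ccccc1` share the same core and differ in two places, so no single step between them is counted here. In a functional assay on HeLa cells (Homo sapiens) for antiproliferative activity, read by MTT assay, with a stated time of 48 h (on this read-out lower numbers stand for stronger inhibition of growth and higher numbers for weaker inhibition of growth), compound 1 gives 12900 nM. Compound 2 in this assay reaches only a limit of the assay, > 50000 nM. Its position on the numbers shown is therefore the weak end: it sits at the limit of > 50000 nM in this assay, at which 1 of the 2 values shown sits, and no number is known for it. Compound 3 `CCOC(=O)c1sc2ccc(N)cc2c1NC(=O)c1ccc(OC)cc1` differs from compound 2 in one place: methoxy in place of hydrogen on an aromatic carbon. Among the measured compounds shown here, no measured pair shows this change alone, so its size in this assay is uncertain; the expectation is a step of an at least 1.2-fold lower number from compound 2 to compound 3 (0.09 log units; that floor lies within the scatter), small and not clearly beyond the usual scatter. Compound 3 is thus expected to give about 40000 nM, within a range of 15000 nM to 100000 nM.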

Compound 3, concentration for 50% growth inhibition: > 50000 nM
Compound 3 was reported as a limit; the forecaster's own chance of this, stated with the estimate: 55%; middle value at least 1.2-fold (0.09 log units) away from the limit.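

In this assay compound 3 gives > 50000 nM, which is a limit of the assay and not a number. With the 4-methoxyphenyl group held fixed, replacing the (1H-imidazol-4-yl)methyl group on the nitrogen with hydrogen gives an at least 3.8-fold higher number from compound 1 to compound 3 (0.58 log units; beyond the scatter), so in this pair that group goes with stronger inhibition of growth. The change from phenyl to 4-methoxyphenyl cannot be read, because both compounds that carry it stop at the limit: the limit of > 50000 nM in this assay, at which 2 of the 3 values shown sit.

From the compounds shown here alone, it remains open whether the gain depends on the imidazole ring or would also appear with a plain benzyl or methyl group on the same nitrogen. The methoxy group's contribution also remains open, since no compound shown pairs the (1H-imidazol-4-yl)methyl group with an unsubstituted phenyl.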